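Serum half-life notes on the azido-nucleoside carbonate series

The compounds below may be only part of what the source reports. "The series", "measured", "known", "first", "only" and "open" are said of these compounds alone.

Of the compounds shown here, three have been measured in an ADME assay on the whole organism (serum) with Homo sapiens as the target; a lower number here means that the compound disappears faster, a higher number that the compound lasts longer. Compound 1 `Cc1cn(C2CC(N=[N+]=[N-])C(COC(=O)OCCCO)O2)c(=O)[nH]c1=O` gives 0.167 h and stands second highest of the three numbers, with compound 3 nearest and compound 2 furthest. Compound 2 `Cc1cn(C2CC(N=[N+]=[N-])C(COC(=O)OCCCCCO)O2)c(=O)[nH]c1=O` gives 0.267 h in this assay, and compound 3 `Cc1cn(C2CC(N=[N+]=[N-])C(COC(=O)OCCCN)O2)c(=O)[nH]c1=O` gives 0.133 h. The steps among them are small: a 1.6-fold higher number from compound 1 to compound 2 (0.20 log units; within the scatter), a 1.3-fold lower number from compound 1 to compound 3 (0.10 log units; within the scatter) and a 2.0-fold lower number from compound 2 to compound 3 (0.30 log units; within the scatter), all within the scatter. Across the three compounds the numbers cluster and none can be told apart from the others on this assay.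

The next compound, compound 4 `Cc1cn(C2CC(N=[N+]=[N-])C(COC(=O)NCCCN)O2)c(=O)[nH]c1=O`, differs from compound 1 in the following way: (3-aminopropyl)amino in place of 3-hydroxypropoxy on a carbonyl carbon. The measured steps all change only the end of the chain and keep the carbonyl group as it stands, so none of them bears directly on this change. What they do show is that the half-life in this assay is confined to a narrow band of values across the three measured compounds. Among the compounds with values here, with no step covering the change at the carbonyl carbon, the expectation for compound 4 is a step of a 1.8-fold higher number from compound 1 to compound 4 (0.25 log units; within the scatter), and compound 4 is estimated to give 0.3 h in this assay, within a range from 0.1 h to 1 h.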

Compound 4, half-life: > 48 h
Compound 4 was reported as a limit; the forecaster's own chance of this, stated with the estimate: 5%; at least 160-fold (2.20 log units) between middle value and limit.
By their numbers in this assay, from the lowest: compounds 3, 1 and 2 (each within the scatter of the next). At a limit, above all of these: compound 4.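

In this assay compound 4 is reported as a limit, not a number: the limit of > 48 h in this assay, at which 1 of the 4 values shown sits.

At the carbonyl carbon, (3-aminopropyl)amino in place of 3-hydroxypropoxy gives an at least 280-fold higher number from compound 1 to compound 4 (2.45 log units; beyond the scatter), (3-aminopropyl)amino in place of (5-hydroxypentyl)oxy gives an at least 170-fold higher number from compound 2 to compound 4 (2.25 log units; beyond the scatter), and (3-aminopropyl)amino in place of 3-aminopropoxy gives an at least 360-fold higher number from compound 3 to compound 4 (2.55 log units; beyond the scatter). Within the data shown here, the last of these pairs is the most telling, since 3-aminopropoxy and (3-aminopropyl)amino differ only in an oxygen exchanged for a nitrogen within a group of the same size, so the amino group on the chain alone does not account for the step; the earlier changes at the end of the chain all stayed within the scatter, and this position is the first to show a step beyond it.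

From the compounds shown here alone, how far the half-life of compound 4 extends past the limit stays open, so the true size of these steps is unknown. Also open, going by these compounds, is whether the carbonyl change holds without the chain amine, as with (3-hydroxypropyl)amino on the same carbonyl carbon, or with a longer chain such as (5-hydroxypentyl)amino.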